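Aryl replacement on the fused core: compound 3 to compound 4

The compounds below may be only part of what the source reports. "The series", "measured", "known", "first", "only" and "open" are said of these compounds alone.

Compound 3 `COc1cc(-c2ccnc3cc(-c4cn(C)c5ccccc45)nn23)cc(OC)c1OC` carries a 1-methyl-1H-indol-3-yl group on the shared core. Among the measured compounds shown here, in a functional assay on A549 cells (Homo sapiens) for inhibition, read by CCK-8 assay, with a stated time of 48 h (on this read-out lower numbers stand for stronger inhibition and higher numbers for weaker inhibition), compound 3 gives 1340 nM, the highest of the three numbers measured so far. Compound 2 `COc1cc(-c2ccnc3cc(-c4ccc(-c5cnn(C)c5)cc4)nn23)cc(OC)c1OC` gives 1150 nM in this assay, a number that sits within the scatter of compound 3. For the measured compounds named here, compound 1 `COc1cc(-c2ccnc3cc(-c4c[nH]c5ccccc45)nn23)cc(OC)c1OC` gives 29 nM in this assay, and the only single-point step recorded, a 46-fold higher number from compound 1 to compound 3 (1.66 log units; beyond the scatter), separates it from compound 3.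

Compound 4 `COc1cc(-c2ccnc3cc(-c4ccc(F)cc4)nn23)cc(OC)c1OC` is not yet measured. Its change from compound 3 is 4-fluorophenyl in place of 1-methyl-1H-indol-3-yl on an aromatic carbon.

The recorded step concerns a methyl in place of hydrogen on an aromatic nitrogen and does not speak to exchanging the whole group at this place, so it bears only loosely on the present change. What the two values of compound 2 and compound 3 show is that a six-membered aromatic ring of carbon only bearing a substituent at this place gives a number close to that of the 1-methyl-1H-indol-3-yl group. On that basis compound 4 is expected to sit near compound 3, with the step of a 1.1-fold higher number from compound 3 to compound 4 (0.05 log units; within the scatter) estimated to stay within the scatter. Compound 4 is therefore estimated at 1500 nM in this assay, with a range from 500 nM to 5000 nM.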

Compound 4, half-maximal inhibitory concentration: 3800 nM
Compound 4: the middle estimate sits 2.5-fold (0.40 log units) below what was measured; low and high end bracket the measured number.
By their numbers in this assay, from the lowest: compound 1; then compounds 2 and 3 (each within the scatter of the next); then compound 4.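

In this assay the change to 4-fluorophenyl gives a 2.8-fold higher number from compound 3 to compound 4 (0.45 log units; beyond the scatter) and the change to fluoro in place of 1-methyl-1H-pyrazol-4-yl gives a 3.3-fold higher number from compound 2 to compound 4 (0.52 log units; beyond the scatter) and therefore a six-membered aromatic ring of carbon only does not by itself hold the number near that of the 1-methyl-1H-indol-3-yl group; the substituent on that ring counts at this place. Against the 1H-indol-3-yl group the exchange gives a 130-fold higher number from compound 1 to compound 4 (2.12 log units; beyond the scatter) which is the largest step in the series so far and leaves compound 4 with the highest number of the four, while the two modest steps show that most of the distance from compound 1 had already been covered by compound 2 and compound 3. Nothing measured here gives a reason for any of these steps.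

Still open, going by these compounds, is whether an amine or a hydroxyl group on the phenyl ring, in place of fluoro, would move the number toward that of compound 2 or further. Also open, on these data alone, is whether the low number of compound 1 depends on the whole 1H-indol-3-yl group or can be kept with a different ring carrying a hydrogen on an aromatic nitrogen.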